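Alkyne arm of the sulfonamide series: trimming to bare ethynyl

The source may report more compounds than this note shows. Statements on the series, on what has been measured and on what is new or still open speak of the compounds shown alone.

Compound 3 `CC(=O)Nc1nc(-c2cccc(NS(=O)(=O)c3ccc(C#CC4CCCCC4)cc3)c2)cs1` in a functional assay on A-375 cells (Homo sapiens) for antiproliferative activity, read by trypan blue exclusion, with a stated time of 48 h, tested at 10 uM (on this read-out higher numbers stand for a weaker effect at the one concentration tested and lower numbers for a stronger effect), gives 1.2%. Compound 1 `CCCCCCC#Cc1ccc(S(=O)(=O)Nc2cccc(-c3csc(NC(C)=O)n3)c2)cc1` in this assay gives 5.8%, and the two lie within the scatter of each other, so no order between them is claimed. Compound 2 `CC(=O)Nc1nc(-c2cccc(NS(=O)(=O)c3cccc(Br)c3)c2)cs1`, which has no triple-bonded carbon at all, gives 36% in this assay, a number well beyond the scatter above both; on the numbers shown compound 3 thus sits at the strong-effect end together with compound 1, and far from compound 2.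

The next step goes to compound 4 `C#Cc1ccc(S(=O)(=O)Nc2cccc(-c3csc(NC(C)=O)n3)c2)cc1`, differing from compound 3 in one place: hydrogen in place of cyclohexyl on a triple-bonded carbon. Among the measured compounds shown here, the only measured step at this position is a number 4.6 percentage points lower from compound 1 to compound 3 (within the scatter), an exchange of one large group on the triple-bonded carbon for another, and it moved nothing. The new step is different in kind: the group is removed altogether, leaving only ethynyl. For the measured compounds named here, no measured pair tests that, but compound 2, with nothing reaching out from that ring, gives 36%, which points towards a weaker effect once the arm is shortened.

Compound 4 is therefore expected to show a weaker effect than compound 3, the estimated step being a number 26.8 percentage points higher from compound 3 to compound 4 (beyond the scatter). The estimate for compound 4 in this assay is 28%, with a range from 8% to 55%.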

Compound 4, a percentage reported as activity, at one concentration (the size of the read-out at that concentration, not a potency): 1.2%
Estimate against measurement, compound 4: 26.8 percentage points above; measured number outside the range, below it.
By their numbers in this assay, from the lowest: compounds 3, 4 and 1 (each within the scatter of the next); then compound 2.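

In this assay the exchange of cyclohexyl for hydrogen on the triple-bonded carbon gives no change at the digits printed from compound 3 to compound 4 (within the scatter) and the exchange of hexyl for hydrogen gives a number 4.6 percentage points lower from compound 1 to compound 4 (within the scatter), so for these compounds neither large group is needed to keep the read-out at this one concentration, and the 2-cyclohexylethynyl to ethynyl change costs nothing measurable. The large gap lies in the exchange on the sulfonyl sulfur, with a number 34.8 percentage points lower from compound 2 to compound 4 (beyond the scatter), but 3-bromophenyl and 4-ethynylphenyl differ in both the group and its numbered place on the ring, so this step does not tell which of the two matters. No measured evidence offers a reason for either result.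

Compounds 1, 3 and 4 are compared at a single concentration, so any difference in potency among them stays hidden. Open too, going by these compounds, is whether the triple bond itself is required, which 4-bromophenyl or 4-ethylphenyl on the sulfonyl sulfur would test, and whether an amine or a carboxylic acid on the triple-bonded carbon would be tolerated as hexyl and cyclohexyl are.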